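Styryl butenolides: trimethoxy variants in the growth inhibition assay

The source may report more compounds than this note shows. Statements on the series, on what has been measured and on what is new or still open speak of the compounds shown alone.

Measured compounds:
compound 1 `COc1ccc(/C=C/C2(C)C=CC(=O)O2)c(OC)c1`, 80100 nM
compound 2 `COc1ccc(/C=C/C2(C)C=CC(=O)O2)cc1OC`, 84100 nM
compound 3 `COc1cc(/C=C/C2(C)C=CC(=O)O2)cc(OC)c1OC`, 179000 nM

All three were run in a functional assay on UACC-62 cells (Homo sapiens) for inhibition, read by sulforhodamine B assay, with a stated time of 48 h; a lower number here means a stronger inhibitor of growth, a higher number a weaker inhibitor of growth. Compound 1 and compound 2 share the same atoms joined differently; how the two cores differ is not broken down here, and their values lie within the scatter of each other. The change from compound 2 to compound 3 is methoxy in place of hydrogen on an aromatic carbon, giving a 2.1-fold higher number from compound 2 to compound 3 (0.33 log units; beyond the scatter).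

Compound 4 `COc1cc(OC)c(/C=C/C2(C)C=CC(=O)O2)c(OC)c1` is not yet measured. Within the data shown here, it differs from compound 1 by methoxy in place of hydrogen on an aromatic carbon, the same kind of change as the one from compound 2 to compound 3, though here the entering methoxy sits ortho to the group of 9 heavy atoms and meta to two methoxy groups rather than ortho to a methoxy group and meta to the larger group. A step like a 2.1-fold higher number from compound 1 to compound 4 (0.31 log units; beyond the scatter) is expected, resting on the step from compound 2 to compound 3 a 2.1-fold higher number from compound 2 to compound 3 (0.33 log units; beyond the scatter). For compound 4 the estimate is 165000 nM, between 90000 nM and 310000 nM.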

Compound 4, concentration for total growth inhibition: 208000 nM
Compound 4: the middle estimate sits 1.3-fold (0.10 log units) below what was measured; the range from low to high includes it.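

In this assay, methoxy in place of hydrogen on an aromatic carbon gives a 2.6-fold higher number from compound 1 to compound 4 (0.41 log units; beyond the scatter) and the size of the step holds across the two cores: the same change on two cores in this assay, a 2.1-fold higher number (0.33 log units; beyond the scatter) from compound 2 to compound 3 and a 2.6-fold higher number (0.41 log units; beyond the scatter) from compound 1 to compound 4, 1.2-fold (0.09 log units) apart, within the scatter of two such steps.

Both pairs therefore move towards weaker inhibition of growth, even though the entering methoxy occupies a different place in each. Among these compounds, this rests on only two pairs in one cell line; it does not show that the step would carry to other cores, and it does not explain why the number rises.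

On these data alone, it remains open whether the rise is specific to methoxy or would also follow another group at the same place. A hydroxyl group, an amine or a fluorine atom on that aromatic carbon would test this.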